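A few compounds are considered here, and "the series" means these few. Any claim that something is new, unique, unknown or untested is made for them only; others in the source may bear on it.

Series notes. The shared core is carried by compound 1 `Fc1ccc(CSc2nnc(-c3ccc4c(c3)OCCO4)o2)cc1` and compound 2 `O=[N+]([O-])c1cccc(CSc2nnc(-c3ccc4c(c3)OCCO4)o2)c1`. In a functional assay on HeLa cells (Homo sapiens) for antiproliferative activity, read by MTT assay, with a stated time of 48 h (on this read-out higher numbers stand for weaker inhibition and lower numbers for stronger inhibition), compound 1 gives 41200 nM, and in this assay compound 2 gives 35600 nM. On these two numbers compound 1 stands alongside compound 2, the gap between them within the usual scatter, so neither is set apart from the other. The next compound is compound 3 `O=[N+]([O-])c1ccc(CSc2nnc(-c3ccc4c(c3)OCCO4)o2)cc1`. Relative to compound 1 the change is nitro in place of fluoro on an aromatic carbon. For the measured compounds named here, no step between measured compounds covers this change, and nothing in the two known numbers points to a shift beyond the scatter: compound 2, which also carries a nitro group, gives 35600 nM in this assay, close to compound 1. For compound 3 the expected step is a 1.2-fold lower number from compound 1 to compound 3 (0.08 log units; within the scatter), small and without a clear direction. Compound 3 is estimated at 34000 nM in this assay, within 15000 nM to 75000 nM.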

Compound 3, half-maximal inhibitory concentration: 27500 nM
Estimate against measurement, compound 3: 1.2-fold (0.09 log units) above; the range from low to high includes it.
By their numbers in this assay, from the lowest: compounds 3, 2 and 1 (each within the scatter of the next).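

In this assay, nitro in place of fluoro on an aromatic carbon, para to a large group, gives a 1.5-fold lower number from compound 1 to compound 3 (0.18 log units; within the scatter). This position therefore takes the group of three heavy atoms and two hydrogen-bond acceptors in place of a single fluorine with no shift beyond the scatter, and this one-place comparison does not separate the two groups. No measurement at hand accounts for the step or ties it to a property of either group.

Going by these compounds, whether an amine, a carboxylic acid or a longer chain at this position would move the number beyond the scatter remains open. For the compounds shown here, with compounds 3, 2 and 1 each within the scatter of the next, no step yet marks this position as one that matters for antiproliferative activity.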